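Weak acetate enones: extending the acetoxy arm

A few compounds are considered here, and "the series" means these few. Any claim that something is new, unique, unknown or untested is made for them only; others in the source may bear on it.

Values in a functional assay on A549 cells (Homo sapiens) for inhibition, read by XTT assay, with a stated time of 48 h; a lower number here means a stronger inhibitor, a higher number a weaker inhibitor:
- compound 1 `CCC(/C=C(\COC(C)=O)C(=O)c1ccc(OC)cc1)CC`: > 100000 nM (a limit)
- compound 2 `COc1ccc(C(=O)/C(=C/C2CCCCC2)COC(C)=O)cc1`: 90000 nM
- compound 3 `CCC(/C=C(\CCOC(C)=O)C(=O)c1ccc(OC)cc1)CC`: not yet measured

Compound 1 has no number of its own, only a limit: the limit of > 100000 nM in this assay, at which 1 of the 2 values shown sits. The change to compound 3 is acetoxymethyl in place of acetoxy on a saturated chain carbon bound to a double-bonded chain carbon. For the measured compounds named here, the only measured step, an at least 1.1-fold lower number from compound 1 to compound 2 (0.04 log units; that floor lies within the scatter), concerns cyclohexyl in place of pentan-3-yl, so it bears on this change only indirectly. Going by the values given here, with that small step as the sole guide, no step beyond the scatter is expected in this assay, in either direction. The estimated step is a number no higher from compound 1 to compound 3 (the limit leaves the size open). A report as a limit is also expected to be quite possible. The estimate for compound 3 is 100000 nM, with an expected range of 45000 nM to 250000 nM.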

Compound 3, half-maximal inhibitory concentration: > 100000 nM
Compound 3: only a limit was reported; the forecaster's own chance of this, stated with the estimate: 60%; the middle value lies on the limit itself.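

Compound 1 and compound 3 both stand only as limits in this assay, so no step between them can be read: the limit of > 100000 nM in this assay, at which 2 of the 3 values shown sit.

The compounds shown leave open whether acetoxymethyl in place of acetoxy on a saturated chain carbon bound to a double-bonded chain carbon changes inhibition at all.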